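The source may report more compounds than this note shows. Statements on the series, on what has been measured and on what is new or still open speak of the compounds shown alone.

Within the data shown here, compound 2 `O=C1N([C@H](CO)c2cccc(Cl)c2)Cc2cc(-c3nc(NC4CCOCC4)ncc3Cl)cn21` is the only member of this set with a numerical result: in a functional assay on COLO 205 cells (Homo sapiens) for antiproliferative activity, read by luminescence, with a stated time of 72 h (a higher number here means a weaker inhibitor, a lower number a stronger inhibitor), compound 2 gives 104 nM. Compound 1 `Cc1cnc(Nc2ccnn2C)nc1-c1ccc2c(c1)CN([C@H](CO)c1cccc(Cl)c1)C2=O` is recorded in this assay as "not active" (no number reported), and compound 3 `Cc1cnc(Nc2ccnn2C)nc1-c1cn2c(c1F)CN([C@H](CO)c1cccc(Cl)c1)C2=O` likewise in this assay as "not active" (no number reported), so neither offers a comparison step. Compound 4 `C[C@H](CO)Nc1ncc(Cl)c(-c2cc3n(c2)C(=O)N([C@H](CO)c2cccc(Cl)c2)C3)n1` differs from compound 2 by a single exchange, (1-(hydroxymethyl)ethyl in place of oxan-4-yl on a nitrogen on an aromatic ring). Among the measured compounds shown here, with no measured step of this sort available, compound 4 is expected to land close to compound 2, the estimated change from compound 2 to compound 4 in this assay being a 1.2-fold higher number from compound 2 to compound 4 (0.06 log units; within the scatter), within the usual scatter. Compound 4 is therefore estimated at 120 nM in this assay, with a range from 40 nM to 400 nM.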

Compound 4, half-maximal inhibitory concentration: "not active" (no number reported)
No number was reported for compound 4; there is nothing to compare the estimate with.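

Among these compounds, compound 4 carries no number, so no step from compound 2 to compound 4 can be read. Nothing shown explains this result. On these data alone, how far the exchange of oxan-4-yl for 1-(hydroxymethyl)ethyl alters activity stays open.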